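A few compounds are considered here, and "the series" means these few. Any claim that something is new, unique, unknown or untested is made for them only; others in the source may bear on it.

Measured in an ADME assay on microsomes from liver (Rattus norvegicus) for metabolic stability, with a stated time of 30 min; a lower number here means that less of the compound is left, a higher number that more of the compound is left:
- Compound 1 `CC(=O)N[C@@H](C)/C=C/c1ccc(Oc2ccc3nc(C(C)C)sc3c2C(F)(F)F)nc1`: 83%
- Compound 2 `CC(=O)N[C@@H](C)/C=C/c1ccc(Oc2ccc3nc(C(C)C)sc3c2Cl)nc1`: 52%
- Compound 3 `CC(=O)N[C@@H](C)/C=C/c1ccc(Oc2ccc3nc(C)sc3c2Cl)nc1`: 75%

Given the usual scatter, compound 3, at 75%, cannot be told apart from compound 1, at 83%. Both values stand clear of the value for compound 2.

Compound 4 `CC(=O)N[C@@H](C)/C=C/c1ccc(Oc2ccc3nc(C(C)(C)O)sc3c2Cl)nc1` keeps the core of compound 3 and changes one group: 1-hydroxy-1-methylethyl in place of methyl on an aromatic carbon. The most relevant evidence is the modest step of a number 23 percentage points higher from compound 2 to compound 3 (beyond the scatter), beyond the scatter, which puts methyl in place of isopropyl on an aromatic carbon. Within the data shown here, the entering 1-hydroxy-1-methylethyl is larger than methyl, as isopropyl is, but no measured compound carries its hydroxy group, so that step is only a loose guide. The large step of a number 31 percentage points lower from compound 1 to compound 2 (beyond the scatter) concerns a different group and bears on this change only weakly.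

A small fall is therefore expected, smaller than the modest step reversed and possibly lost in the scatter. The expected change is a number 7 percentage points lower from compound 3 to compound 4 (within the scatter). Compound 4 is estimated at 68%, with an expected range of 48% to 85%.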

Compound 4, percent of the compound remaining: 96%
Estimate against measurement, compound 4: 28 percentage points below; the measured number lies above the stated range.
By their numbers in this assay, from the lowest: compound 2; then compounds 3 and 1 (each within the scatter of the next); then compound 4.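

Putting 1-hydroxy-1-methylethyl in place of methyl at this position gives a number 21 percentage points higher from compound 3 to compound 4 (beyond the scatter) in this assay, so a larger group here need not lower the number. The comparison with the isopropyl compound is sharper: hydroxy in place of hydrogen on that one carbon gives a number 44 percentage points higher from compound 2 to compound 4 (beyond the scatter), the largest step among these compounds. No measurement shown here explains why this hydroxy group has such an effect.

On these data alone, it remains open whether the same result would follow with a methoxy group or an amine on that carbon, or with a longer chain carrying the hydroxy group. Among the compounds shown, the hydroxy group appears only with chloro on the core, so its effect with trifluoromethyl in place of chloro also remains open.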